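Phenol in place of hydroxyethoxyphenyl on the diaryl carbon

This account rests on a few compounds, and the source may have more. Where it says the series, first, only, none or still open, it means among the compounds named here.

Working notes on the series. In a functional assay on MCF7 cells (Homo sapiens) for inhibition, read by sulforhodamine B assay, with a stated time of 48 h (on this read-out lower numbers stand for stronger inhibition and higher numbers for weaker inhibition), compound 1 `COc1ccc(C(c2ccc(OC(C)CN(C)C)cc2)c2cccc3ccccc23)c(OC)c1OC` gives 13100 nM and compound 2 `COc1ccc(C(OCc2ccccc2)c2cccc3ccccc23)c(OC)c1OC` gives 14100 nM. Compound 3 `COc1ccc(C(c2ccc(OCCO)cc2)c2cccc3ccccc23)c(OC)c1OC` reaches only a limit in this assay, > 20000 nM. This is the limit of > 20000 nM in this assay, at which 1 of the 3 values shown sits. The two steps that end at compound 3 are an at least 1.5-fold higher number from compound 1 to compound 3 (0.18 log units; that floor lies within the scatter) and an at least 1.4-fold higher number from compound 2 to compound 3 (0.15 log units; that floor lies within the scatter); both run towards weaker inhibition, yet each floor lies within the scatter, and as compound 3 stands at a limit their true size is not known.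

Compound 4 `COc1ccc(C(c2ccccc2O)c2cccc3ccccc23)c(OC)c1OC` is not yet measured. It differs from compound 3 by 2-hydroxyphenyl in place of 4-(2-hydroxyethoxy)phenyl on a saturated chain carbon bound to two aromatic carbons. Among the measured compounds shown here, of the measured steps only the one from compound 2 to compound 3 touches the same place, the group on the saturated chain carbon, and there a benzyloxy was exchanged for a 4-(2-hydroxyethoxy)phenyl; no measured step exchanges the hydroxyethoxy arm for a hydroxyl directly on the ring. The data therefore give no direction, and a step from a limit cannot be sized. Compound 4 is expected at 20000 nM, within 8000 nM to 50000 nM. The step of a number no higher from compound 3 to compound 4 (the limit leaves the size open) is accordingly expected to be none beyond the scatter, with the caution that compound 3 is only a limit and a number for compound 4 may again fail to appear.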

Compound 4, half-maximal inhibitory concentration: 16600 nM
For compound 4 the middle estimate is 1.2-fold (0.08 log units) above the measured one, and the stated range covers the measured number.
By their numbers in this assay, from the lowest: compounds 1, 2 and 4 (each within the scatter of the next). At a limit, above all of these: compound 3.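

In this assay, the 2-hydroxyphenyl on a saturated chain carbon bound to two aromatic carbons gives compound 4 a measured number, whereas the 4-(2-hydroxyethoxy)phenyl of compound 3 reaches only a limit. The exchange is an at least 1.2-fold lower number from compound 3 to compound 4 (0.08 log units; that floor lies within the scatter), and its true size stays open because one end of it is a limit: the limit of > 20000 nM in this assay, at which 1 of the 4 values shown sits.
Set against the benzyloxy of compound 2, the same group gives a 1.2-fold higher number from compound 2 to compound 4 (0.07 log units; within the scatter), so this first fully readable step at this place, with an aryl group bearing a hydroxyl in place of benzyloxy, shows no change beyond the scatter.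

The compounds shown leave open what the hydroxyl of the 2-hydroxyphenyl contributes, which a plain phenyl or a methoxyphenyl at the same place would test. Going by these compounds, it is equally open whether a carboxylic acid in place of the terminal hydroxyl on the 2-hydroxyethoxy arm of compound 3 would give a number rather than a limit in this assay.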